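Changing the amide end of a weak inhibitor

A few compounds are considered here, and "the series" means these few. Any claim that something is new, unique, unknown or untested is made for them only; others in the source may bear on it.

compound 1 `CC1CCN(C(=O)CCCNC(=O)c2ccc(S(C)(=O)=O)c([N+](=O)[O-])c2)CC1`: > 60000 nM
compound 2 `CS(=O)(=O)c1ccc(C(=O)NCCCC(=O)N2CCC(c3ccccc3)CC2)cc1[N+](=O)[O-]`: > 60000 nM

In an assay on isolated protein for inhibition of vitamin D3 receptor (Homo sapiens), read by fluorescence polarization (a higher number here means a weaker inhibitor, a lower number a stronger inhibitor), compound 1 gives only a limit, > 60000 nM. Compound 2 likewise gives only a limit, > 60000 nM. For the measured compounds named here, the single measured step, phenyl in place of methyl on a saturated ring carbon, is a step that the two limits leave unreadable from compound 1 to compound 2, so its size cannot be read, as both values sit at the limit of > 60000 nM in this assay, at which 2 of the 2 values shown sit.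

Compound 3 `CN(Cc1ccccc1F)C(=O)CCCNC(=O)c1ccc(S(C)(=O)=O)c([N+](=O)[O-])c1` differs from compound 1 by (2-fluorobenzyl)(methyl)amino in place of 4-methylpiperidin-1-yl on a carbonyl carbon. Going by the values given here, no measured step bears on this change, and the one step that is known is itself unreadable; the two values of compound 1 and compound 2 show only that neither reaches a measurable number. There is therefore no ground to expect a step beyond the scatter in this assay in either direction, and the most likely outcome is another limit.

Compound 3 is thus expected to give about 100000 nM, between 30000 nM and 400000 nM. For compound 3 this means an expected step that the limit leaves unreadable from compound 1 to compound 3.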

Compound 3, half-maximal inhibitory concentration: > 60000 nM
Compound 3 was reported as a limit; the forecaster's own chance of this, stated with the estimate: 85%; the middle value lies beyond the limit too.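

In this assay compound 3 gives > 60000 nM, which is a limit and not a number. Compound 1 also gives only a limit, so no step from compound 1 to compound 3 can be read: the limit of > 60000 nM in this assay, at which 3 of the 3 values shown sit.

The compounds shown leave open whether any group at the amide end gives a measurable value in this assay.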